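A few compounds are considered here, and "the series" means these few. Any claim that something is new, unique, unknown or untested is made for them only; others in the source may bear on it.

Measured so far:
compound 1 `Cc1nc(S(C)(=O)=O)ccc1Oc1ncnc(OC2CCN(C(=O)OC(C)(C)C#N)CC2)c1F`: 1320 nM
compound 2 `Cc1nc(S(C)(=O)=O)ccc1Oc1ncnc(OC2CCN(C(=O)SC3(C)CC3)CC2)c1F`: 166 nM
compound 3 `Cc1nc(S(C)(=O)=O)ccc1Oc1ncnc(OC2CCN(C(=O)C(F)(F)F)CC2)c1F`: 880 nM

Of the compounds shown here, three built on one shared core have been tested in a functional assay on isolated protein for inhibition of Glucose-dependent insulinotropic receptor (Rattus norvegicus), read by HTRF and cAMP accumulation; a lower number here means that less compound is needed, a higher number that more compound is needed for the effect. In this assay compound 1 gives 1320 nM, the highest of the three numbers. Compound 2 gives 166 nM and compound 3 gives 880 nM. The three differ only in the group on a carbonyl carbon whose other neighbour is an amide-type nitrogen in a ring. Exchanging the open chain of compound 1 for a small carbon ring gave an 8.0-fold lower number from compound 1 to compound 2 (0.90 log units; beyond the scatter), while exchanging it for trifluoromethyl gave a 1.5-fold lower number from compound 1 to compound 3 (0.18 log units; within the scatter).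

Compound 4 `Cc1nc(S(C)(=O)=O)ccc1Oc1ncnc(OC2CCN(C(=O)C3(F)CCC3)CC2)c1F` is not yet measured. It differs from compound 1 in one place: a group of 5 heavy atoms (4 carbon, 1 fluorine; one four-membered non-aromatic ring of carbon only) in place of a group of 6 heavy atoms (4 carbon, 1 nitrogen, 1 oxygen; no ring), on a carbonyl carbon.

For the measured compounds named here, the step that bears most on this change is the one to compound 2, where a small carbon ring entered on the same carbonyl carbon and the number dropped well beyond the scatter. The step to compound 3, with no ring entering, stayed within the scatter. Compound 4 also brings a small carbon ring, so a lower number is expected, though not necessarily as large a drop as that seen for compound 2: the expected step is a 3.3-fold lower number from compound 1 to compound 4 (0.52 log units; beyond the scatter). Compound 4 is therefore estimated at 400 nM, with a range from 150 nM to 1100 nM.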

Compound 4, half-maximal effective concentration: 123 nM
Estimate against measurement, compound 4: 3.3-fold (0.51 log units) above; measured number below the stated range.
By their numbers in this assay, from the lowest: compounds 4 and 2 (each within the scatter of the next); then compounds 3 and 1 (each within the scatter of the next).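

The step of an 11-fold lower number from compound 1 to compound 4 (1.03 log units; beyond the scatter) and the step of a 7.2-fold lower number from compound 3 to compound 4 (0.85 log units; beyond the scatter) show that, in this assay, a low number on this carbonyl carbon does not depend on the sulfur in the group of compound 2, since the group that enters compound 4 holds carbon and fluorine only. The step of a 1.3-fold lower number from compound 2 to compound 4 (0.13 log units; within the scatter) lies within the scatter, so a four-membered carbon ring bearing fluorine and a three-membered carbon ring carried with sulfur stand level here, while the trifluoromethyl group of compound 3, which also holds fluorine but no ring, stays well behind compound 4. Nothing among the data shown explains why these groups differ.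

The compounds shown do not separate the part played by the ring from that played by its fluorine, and a plain cyclobutyl group without fluorine would address this directly. Going by these compounds, how ring size matters also remains open, as a cyclopentyl or cyclohexyl group on the same carbonyl carbon would show whether the low numbers extend to larger carbon rings.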